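This account rests on a few compounds, and the source may have more. Where it says the series, first, only, none or still open, it means among the compounds named here.

Compound 1 `COc1ccccc1NC(=O)c1c(NC(=O)C(F)(F)F)sc2c1CCCCC2` belongs to a small set of amides examined in an ADME assay on THP-1 cells (Homo sapiens) for cytotoxicity; on this read-out higher numbers stand for lower toxicity in this test and lower numbers for higher toxicity in this test. In this assay compound 1 reaches only the limit of the assay, > 50000 nM. Compound 2 `COc1ccc(NC(=O)c2c(NC(=O)c3ccccc3)sc3c2CCCCC3)cc1` likewise gives a limit in this assay, > 50000 nM. Among the compounds with values here, both values thus sit at the limit of > 50000 nM in this assay, at which 2 of the 2 values shown sit, and no measured step between them exists. Compound 3 `O=C(Nc1ccc(C(F)(F)F)cc1)c1c(NC(=O)C(F)(F)F)sc2c1CCCCC2` differs from compound 1 by 4-(trifluoromethyl)phenyl in place of 2-methoxyphenyl on an amide-type nitrogen. Within the data shown here, with no measured step to draw on, the change expected in this assay is a step that the limit leaves unreadable from compound 1 to compound 3, none beyond the scatter. Compound 3 is accordingly estimated at 60000 nM, with a range from 20000 nM to 200000 nM.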

Compound 3, half-maximal cytotoxic concentration: 17200 nM
For compound 3 the middle estimate is 3.5-fold (0.54 log units) above the measured one; the whole stated range lies above it.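

In this assay compound 3 is the first of the compounds shown to give a number rather than a limit, so the group on this amide-type nitrogen can move the read-out: 4-(trifluoromethyl)phenyl in place of 2-methoxyphenyl gives an at least 2.9-fold lower number from compound 1 to compound 3 (0.46 log units; beyond the scatter). The full size of this step cannot be read because compound 1 stands at a limit of the assay: the limit of > 50000 nM in this assay, at which 2 of the 3 values shown sit.

Which part of the exchanged group carries the step stays open. Also open, going by these compounds, is what an amine or a carboxylic acid on the phenyl ring at this nitrogen would do in this assay.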